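The compounds below may be only part of what the source reports. "The series", "measured", "known", "first", "only" and "open" are said of these compounds alone.

Measured in a functional assay on HeLa cells (Homo sapiens) for cytotoxicity, read by MTT assay, with a stated time of 24 h; on this read-out higher numbers stand for weaker inhibition and lower numbers for stronger inhibition:
compound 1, `C=CC1=C(C(=O)NCc2ccc(C)cc2)C(c2ccc(F)cc2)OC1`, gives > 100000 nM, which is a limit of the assay and not a number.
compound 2, `C=CC1=C(C(=O)NC(C)(C)C)C(c2ccc(Cl)c(Cl)c2)OC1`, gives > 100000 nM, again a limit of the assay.
compound 3, `C=CC1=C(C(=O)NCc2ccc(OC)c(OC)c2)C(c2ccc(F)cc2)OC1`, gives > 100000 nM, also a limit of the assay.

Compound 3 therefore stands nowhere in particular on the numbers shown: its value is a limit, and the two other values shown are limits as well, so that the limit of > 100000 nM in this assay, at which 3 of the 3 values shown sit, describes every entry in the set. Within the data shown here, no step between measured compounds can be drawn, and nothing in these three values distinguishes one compound from another.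

Compound 4, `C=CC1=C(C(=O)NCc2ccc(OC)c(OC)c2)C(c2ccc(OC)cc2)OC1`, has not been measured in this assay. It differs from compound 3 by methoxy in place of fluoro on an aromatic carbon, the same difference read one bond further out being 4-fluorophenyl to 4-methoxyphenyl.

Among the measured compounds shown here, with three limits and no measured step, the change from compound 3 to compound 4 is expected to give no step beyond the scatter in this assay, in no direction, a step that the limit leaves unreadable from compound 3 to compound 4. Compound 4 is thus expected to sit at about 150000 nM, within 50000 nM to 500000 nM, most likely reported as a limit again.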

Compound 4, half-maximal inhibitory concentration: > 100000 nM
Compound 4 gave a limit, no number; the forecaster's own chance of this, stated with the estimate: 85%; the middle value does not contradict the limit.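

In this assay compound 4 gives > 100000 nM as a limit and not a number. Among these compounds, compound 3 sits at a limit as well, so no step between compound 3 and compound 4 can be read: the limit of > 100000 nM in this assay, at which 4 of the 4 values shown sit.

The compounds shown leave open whether fluoro and methoxy differ at all in this assay and whether any compound of this series reaches a measurable value.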